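The compounds below may be only part of what the source reports. "The series", "measured", "known", "first", "only" and "open" are said of these compounds alone.

Measured so far in an ADME assay on 184B5 cells (Homo sapiens) for cytotoxicity, read by MTT assay, with a stated time of 72 h; on this read-out lower numbers stand for stronger inhibition of growth and higher numbers for weaker inhibition of growth:
compound 1 `CCCCC[Se]c1nc(NCc2ccccc2)c2ccccc2n1` gives 70900 nM;
compound 2 `CSc1nc(NCc2ccccc2)c2ccccc2n1` gives 28900 nM.

Compound 2 stands at the lowest of the two numbers; the only other one, compound 1, lies above it, as a 2.5-fold lower number from compound 1 to compound 2 (0.39 log units; beyond the scatter) shows. Compound 3 `C[Se]c1nc(NCc2ccccc2)c2ccccc2n1` is not yet measured; it differs from compound 2 by a group of 2 heavy atoms (1 carbon, 1 selenium; no ring) in place of a group of 2 heavy atoms (1 carbon, 1 sulfur; no ring), on an aromatic carbon. Going by the values given here, the one measured step that bears on this, a 2.5-fold lower number from compound 1 to compound 2 (0.39 log units; beyond the scatter), bundles a change of chalcogen with a change of chain length, so it speaks only partly to this move. A small step, if any, is expected here: compound 3 is estimated at 36000 nM (range 15000 nM to 85000 nM), which means an expected 1.2-fold higher number from compound 2 to compound 3 (0.10 log units; within the scatter).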

Compound 3, concentration for 50% growth inhibition: 3720 nM
Compound 3: the middle estimate sits 9.7-fold (0.99 log units) above what was measured; measured number below the stated range.
By their numbers in this assay, from the lowest: compound 3; then compound 2; then compound 1.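

In this assay, the chalcogen on the aromatic carbon between two ring nitrogen atoms matters by itself: with the methyl end unchanged, selenium in place of sulfur gives a 7.8-fold lower number from compound 2 to compound 3 (0.89 log units; beyond the scatter). Chain length also counts on selenium, since hydrogen in place of butyl on the saturated chain carbon bound to selenium gives a 19-fold lower number from compound 1 to compound 3 (1.28 log units; beyond the scatter). Nothing at hand accounts for either step. As far as these compounds go, whether sulfur responds to chain length in the same way remains open. So does how an ethyl chain, or an amine at this position, would compare.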